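The compounds below may be only part of what the source reports. "The series", "measured", "known", "first", "only" and "open" are said of these compounds alone.

Compound 1, `CCCCC#Cc1cncc(OC[C@@H]2CCCN2C)c1`, was tested in an assay on a protein complex for binding affinity to Neuronal acetylcholine receptor; alpha3/beta2 (Homo sapiens) (on this read-out lower numbers stand for stronger inhibition and higher numbers for weaker inhibition), where compound 1 gives 21 nM. Within the data shown here, its only measured neighbour is compound 2, `C#Cc1cncc(OC[C@@H]2CCCN2C)c1`, which in this assay gives 8.2 nM. The step of a 2.6-fold lower number from compound 1 to compound 2 (0.41 log units; beyond the scatter) comes with hydrogen in place of butyl on a triple-bonded carbon. Of the two numbers at hand, compound 1 therefore carries the higher one. Compound 3, `CN1CCC[C@H]1COc1cncc(C#Cc2ccccc2)c1`, is not yet measured; it differs from compound 1 by phenyl in place of butyl on a triple-bonded carbon. Among the measured compounds shown here, the single measured step bears on this change only loosely: it removed the same butyl and lowered the number by a modest amount. For the measured compounds named here, no measured pair shows what a phenyl does at this position, so the direction is uncertain. A step of a 1.4-fold lower number from compound 1 to compound 3 (0.15 log units; within the scatter) is expected, modest and leaning toward a lower number. Compound 3 is expected to give 15 nM in this assay, within a range from 5 nM to 50 nM.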

Compound 3, inhibition constant: 8.6 nM
Compound 3: the middle estimate sits 1.7-fold (0.24 log units) above what was measured; the range from low to high includes it.
By their numbers in this assay, from the lowest: compounds 2 and 3 (each within the scatter of the next); then compound 1.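

In this assay, phenyl in place of butyl on a triple-bonded carbon gives a 2.4-fold lower number from compound 1 to compound 3 (0.39 log units; beyond the scatter) and so matches the direction seen when butyl gave way to hydrogen. Phenyl has more heavy atoms than butyl and hydrogen has none, so across these three compounds the number does not follow the heavy-atom count of the group, and a 1.0-fold higher number from compound 2 to compound 3 (0.02 log units; within the scatter) leaves hydrogen and phenyl indistinguishable here. Nothing at hand explains why compound 1, with its butyl, stands apart from the other two.

Going by these compounds, it remains open whether a short chain such as methyl or propyl behaves like butyl or like hydrogen. Also open, on these data alone, is whether a fluorine or a methoxy group on the phenyl, or a pyridine ring in its place, would keep the number of compound 3 or shift it.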